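Adding a chloro to the lower-clearance compound

The source may report more compounds than this note shows. Statements on the series, on what has been measured and on what is new or still open speak of the compounds shown alone.

- compound 1 `CN(Cc1ccccc1)S(=O)(=O)c1ccc(NC(=O)NCc2ccncc2)cc1` (43 mL/min/kg)
- compound 2 `O=C(NCc1cn[nH]c1)Nc1ccc(S(=O)(=O)c2ccccc2)cc1` (8 mL/min/kg)

Compound 2 has the lower of the two numbers in an ADME assay on the whole organism (Mus musculus) for pharmacokinetics, at a dose of 1 mg/kg by the intravenous route (on this read-out higher numbers stand for fast clearance and lower numbers for slow clearance), and compound 1 lies well beyond the usual scatter from it. These two compounds differ in more than one place, so their gap does not show what a single small change does. Compound 3 `O=C(NCc1cn[nH]c1)Nc1ccc(S(=O)(=O)c2ccc(Cl)cc2)cc1` has chloro in place of hydrogen on an aromatic carbon of compound 2 (chloro in place of hydrogen on an aromatic carbon). Going by the values given here, no comparable measured step exists, so no change beyond the scatter is expected in this assay, and the estimated no change at the digits printed from compound 2 to compound 3 (within the scatter) is small. Compound 3 is expected at 8 mL/min/kg (estimated range 3.5 mL/min/kg to 18 mL/min/kg).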

Compound 3, clearance: 3 mL/min/kg
Beside the measured number, compound 3's estimate is 2.7-fold (0.43 log units) above it, and the stated range ends above it.
By their numbers in this assay, from the lowest: compound 3; then compound 2; then compound 1.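

In this assay the change from phenyl to 4-chlorophenyl gives a 2.7-fold lower number from compound 2 to compound 3 (0.43 log units; beyond the scatter) and so shows that this position on the ring is not neutral for clearance. A single added chlorine is enough to move the number beyond the usual scatter, and here it moves it lower. No measurement at hand explains this fall. On these data alone, whether fluoro, methoxy or an amine at the same place would give a similar step remains open. So does whether chloro would do the same on the core of compound 1.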